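The source may hold more compounds than are shown below. What is called first, only, known or untested is meant among the compounds shown, and "the series" means these compounds.

Working notes on a small set built on the shared core of compound 1 `COc1ccccc1CNc1nc2c(N)ncnc2n1[C@@H]1O[C@H](CO)[C@@H](O)[C@H]1O`, all tested in an assay on COS-7 cells for inhibition of sodium/nucleoside cotransporter 2 (Homo sapiens), read by scintillation counting, in the presence of a further agent that is not named here; on this read-out lower numbers stand for stronger inhibition and higher numbers for weaker inhibition. Compound 1 gives only a limit of the assay, > 100000 nM, and no number. Compound 2 `Nc1ncnc2c1nc(NCc1ccccc1-c1ccccc1)n2[C@@H]1O[C@H](CO)[C@@H](O)[C@H]1O` likewise gives only a limit, > 100000 nM. Among the measured compounds shown here, compound 3 `COc1cccc(CNc2nc3c(N)ncnc3n2[C@@H]2O[C@H](CO)[C@@H](O)[C@H]2O)c1` gives 13000 nM, the only number among the three measured compounds. The difference between compound 1 and compound 3 is 3-methoxyphenyl in place of 2-methoxyphenyl on a saturated chain carbon bound to a nitrogen on an aromatic ring, and it reads as an at least 7.6-fold lower number from compound 1 to compound 3 (0.88 log units; beyond the scatter). Compound 2 differs from compound 1 by phenyl in place of methoxy on an aromatic carbon; because of the limit of > 100000 nM in this assay, at which 2 of the 3 values shown sit, that step stays unreadable, a step that the two limits leave unreadable from compound 1 to compound 2.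

Compound 4 `Nc1ncnc2c1nc(NCc1cccc(-c3ccccc3)c1)n2[C@@H]1O[C@H](CO)[C@@H](O)[C@H]1O` is not yet measured in this assay. From compound 3 it differs by phenyl in place of methoxy on an aromatic carbon. This is the same kind of change as from compound 1 to compound 2, but not the same: there the entering group sits ortho to a large group, here meta to a large group. The earlier step gives no size to lean on, since both of its ends sit at the limit. The estimate for compound 4 therefore rests on compound 3 alone, which gives 13000 nM. The expected step is a 1.1-fold lower number from compound 3 to compound 4 (0.03 log units; within the scatter), with wide uncertainty in either direction. Compound 4 is estimated at 12000 nM, expected to fall between 2000 nM and 100000 nM.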

Compound 4, half-maximal inhibitory concentration: 21000 nM
Estimate against measurement, compound 4: 1.8-fold (0.24 log units) below, and the stated range covers the measured number.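

In this assay, phenyl in place of methoxy on an aromatic carbon, meta to a large group, gives a 1.6-fold higher number from compound 3 to compound 4 (0.21 log units; within the scatter), so the two values cannot be told apart and, on this single pair, the replacement is tolerated on the core of compound 3 without a readable cost or gain. The same replacement on the core of compound 1, from compound 1 to compound 2, cannot be read, because both of its ends sit at a limit and not at a number: the limit of > 100000 nM in this assay, at which 2 of the 4 values shown sit. From the compounds shown here alone, the series therefore holds one readable instance of this change, which shows how it behaves on one core only and does not show whether that result carries over to another core, where its size remains unknown.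

The compounds shown leave open whether any other group on this aromatic carbon, such as an amine, a carboxylic acid or a longer alkyl chain, would give a step beyond the scatter on the core of compound 3. They also leave open how such a group would read on the core of compound 1, where a number rather than a limit would be needed for any comparison.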